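A few compounds are considered here, and "the series" means these few. Any claim that something is new, unique, unknown or untested is made for them only; others in the source may bear on it.

Measured in a functional assay on SW-620 cells (Homo sapiens) for inhibition, read by MTT assay, with a stated time of 72 h; a higher number here means a weaker inhibitor, a lower number a stronger inhibitor:
- compound 1 `COc1cc(Oc2cccc(Nc3ccccc3)c2)cc(OC)c1CNCc1ccccc1` gives 7490 nM
- compound 2 `COc1cc(Oc2cccc(Nc3ccccc3)c2)cc(OC)c1CNCc1ccc(F)cc1` gives 6770 nM
- compound 3 `COc1cc(Oc2cccc(Nc3ccccc3)c2)cc(OC)c1CNCCNC(C)=O` gives 11900 nM

Compound 3 stands within the scatter of both other compounds, as shown by a 1.6-fold higher number from compound 1 to compound 3 (0.20 log units; within the scatter) and a 1.8-fold higher number from compound 2 to compound 3 (0.24 log units; within the scatter). The next compound is compound 4 `CCN1CCN(Cc2c(OC)cc(Oc3cccc(Nc4ccccc4)c3)cc2OC)CC1`, with 4-ethylpiperazin-1-yl in place of (2-acetamidoethyl)amino on a saturated chain carbon bound to an aromatic carbon.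

The two steps to compound 3 changed the group at this same part of the molecule, and neither left the scatter. The fluoro step, a 1.1-fold lower number from compound 1 to compound 2 (0.04 log units; within the scatter), also stayed within it. None of the three measured compounds carries a ring at the amine nitrogen, so the data do not test this feature directly. In this assay, no step beyond the scatter is therefore expected.

The estimated step is a 1.6-fold lower number from compound 3 to compound 4 (0.20 log units; within the scatter). Compound 4 is expected at 7500 nM, with an estimated range of 3000 nM to 16000 nM.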

Compound 4, half-maximal inhibitory concentration: > 20000 nM
Compound 4 gave a limit, no number; the forecaster's own chance of this, stated with the estimate: 5%; at least 2.6-fold (0.42 log units) between middle value and limit.
By their numbers in this assay, from the lowest: compounds 2, 1 and 3 (each within the scatter of the next). At a limit, above all of these: compound 4.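

In this assay compound 4 gives > 20000 nM, which is a limit of the assay and not a number. For the compounds shown here, replacing benzylamino or (4-fluorobenzyl)amino on this saturated chain carbon with 4-ethylpiperazin-1-yl gives the first steps beyond the scatter, an at least 2.6-fold higher number from compound 1 to compound 4 (0.42 log units; beyond the scatter) and an at least 2.9-fold higher number from compound 2 to compound 4 (0.47 log units; beyond the scatter), so this position is not indifferent to every change, as the earlier compounds alone might have suggested. Against compound 3 the floor stays within the scatter, an at least 1.6-fold higher number from compound 3 to compound 4 (0.22 log units; that floor lies within the scatter), so the size of that step remains unknown.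

The entering group has a six-membered non-aromatic ring and 0 hydrogen-bond donors, and the compounds shown do not separate these two features. Diethylamino would carry no ring and no donor, while unsubstituted piperazin-1-yl would keep the ring and add a donor, so either group would help to tell them apart.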